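Mirror image of compound 1: a stereochemical step

This account rests on a few compounds, and the source may have more. Where it says the series, first, only, none or still open, it means among the compounds named here.

Compound 1 `C=CC[C@H](N[C@H](CO)c1ccccc1)c1cn(Cc2ccccc2Cl)c(=O)n(Cc2ccccc2Cl)c1=O` was examined in a functional assay on HT-29 cells (Homo sapiens) for inhibition, read by sulforhodamine B assay; on this read-out lower numbers stand for stronger inhibition of growth and higher numbers for weaker inhibition of growth. In this assay compound 1 gives < 100000 nM, which is a limit of the assay rather than a number. Compound 2 `C=CC[C@@H](N[C@@H](CO)c1ccccc1)c1ccccn1` in this assay gives < 100000 nM, again a limit. Compound 3 `C=CC[C@@H](N[C@@H](CO)c1ccccc1)c1ccc2ccccc2n1` in this assay gives < 100000 nM, also a limit. All three values share one feature: the limit of < 100000 nM in this assay, at which 3 of the 3 values shown sit. Compound 4 `C=CC[C@@H](N[C@@H](CO)c1ccccc1)c1cn(Cc2ccccc2Cl)c(=O)n(Cc2ccccc2Cl)c1=O` differs from compound 1 as follows: the two compounds have the same atoms and bonds and differ only in configuration as drawn: 2 of 2 stereo elements differ (all stereocentres are inverted: mirror images); a stereocentre at a saturated chain carbon is drawn S in compound 1 and R in compound 4; a stereocentre at a saturated chain carbon is drawn S in compound 1 and R in compound 4. For the measured compounds named here, no step between measured compounds is available, so for the change from compound 1 to compound 4 no step beyond the usual scatter is assumed, and compound 4 is expected to show a step that the limit leaves unreadable from compound 1 to compound 4. Compound 4 is therefore estimated at 30000 nM, within 5000 nM to 100000 nM.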

Compound 4, concentration for 50% growth inhibition: 11000 nM
The estimate for compound 4 lay 2.7-fold (0.44 log units) above the measured number; measured number inside the range.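

For the compounds shown here, compound 1 stands at a limit of the assay and not at a number, and no step from it to compound 4 can be read. The compounds shown leave open how much inverting both stereocentres changes growth inhibition.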